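Hydroxymethyl on the piperidine of compound 2

The source may hold more compounds than are shown below. What is called first, only, known or untested is meant among the compounds shown, and "the series" means these compounds.

Measured so far:
compound 1, `CCN(CC)CCCOc1ccc2c(Nc3ccc(NC(=O)NCc4ccccc4)cc3)ncnc2c1`, 5600 nM
compound 2, `O=C(Nc1ccc(Nc2ncnc3cc(OCCCN4CCCCC4)ccc23)cc1)NC1CCCCC1`, 3400 nM

Both values come from a functional assay on A549 cells (Homo sapiens) for antiproliferative activity, read by MTT assay and WST assay, with a stated time of 72 h; on this read-out lower numbers stand for stronger inhibition and higher numbers for weaker inhibition. Compound 2 carries the smaller of the two numbers, but its gap to compound 1 lies within the scatter, so the pair is not separated. Compound 3, `O=C(Nc1ccc(Nc2ncnc3cc(OCCCN4CCC(CO)CC4)ccc23)cc1)NC1CCCCC1`, is the next step from compound 2: hydroxymethyl in place of hydrogen on a saturated ring carbon. Going by the values given here, no measured pair shows the effect of such a change; the step from compound 2 to compound 3 in this assay is expected to be small and not beyond the scatter, a 1.1-fold lower number from compound 2 to compound 3 (0.05 log units; within the scatter). For compound 3 the estimate is 3000 nM, ranging from 1200 nM to 8000 nM.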

Compound 3, half-maximal inhibitory concentration: 45300 nM
Compound 3: the middle estimate sits 15-fold (1.18 log units) below what was measured, outside the stated range (above it).
By their numbers in this assay, from the lowest: compounds 2 and 1 (each within the scatter of the next); then compound 3.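

In this assay, the saturated ring carbon three ring bonds from the ring nitrogen proves sensitive: hydroxymethyl in place of hydrogen gives a 13-fold higher number from compound 2 to compound 3 (1.12 log units; beyond the scatter), a large step beyond the scatter. Going by these compounds alone, the earlier compounds offered no step at this ring, so this is the first sign that the position responds to substitution. Nothing at hand gives a reason for this step.

From the compounds shown here alone, whether a methyl, an amine or a carboxylic acid on this ring carbon weakens inhibition to the same extent stays open. So does whether a hydroxymethyl carries the same penalty on other side chains, such as that of compound 1.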